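The compounds below may be only part of what the source reports. "The series", "measured", "known", "first", "only" and "open" are said of these compounds alone.

Measured compounds:
Compound 1 `CC(C)=CCC/C(C)=C/CC1Cc2c(OCCCNC(=O)c3cccs3)cc(=O)n(CCCO)c2CC1(C)C`: 72.8%
Compound 2 `COc1cccc(NC(=O)Oc2cc(=O)n(CCCO)c3c2CC(C/C=C(\C)CCC=C(C)C)C(C)(C)C3)c1`: 47%
Compound 3 `CC(C)=CCC/C(C)=C/CC1Cc2c(OC(=O)Nc3ccc(F)cc3F)cc(=O)n(CCCO)c2CC1(C)C`: 33.7%

All three share one core and were measured in a functional assay on PANC-1 cells (Homo sapiens) for inhibition, read by MTT assay, with a stated time of 24 h, tested at 10 uM; a lower number here means less inhibition, a higher number more inhibition at the concentration tested (going by the name of the read-out). Compound 3 stands lowest of the three numbers; its nearest neighbour is compound 2, and compound 1 lies furthest from it. The steps that lead to compound 3 were a number 39.1 percentage points lower from compound 1 to compound 3 (beyond the scatter) and a number 13.3 percentage points lower from compound 2 to compound 3 (beyond the scatter), both beyond the scatter.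

Compound 4 `CC(C)=CCC/C(C)=C/CC1Cc2c(OC(=O)Nc3ccc(F)c(Cl)c3)cc(=O)n(CCCO)c2CC1(C)C` has not yet been measured. It differs from compound 3 in one place: 3-chloro-4-fluorophenyl in place of 2,4-difluorophenyl on an amide-type nitrogen

Among the compounds with values here, of the measured steps, only the one from compound 2 to compound 3 bears on this change, since it too swapped one aryl group for another on the amide-type nitrogen, and it moved the read-out by a number 13.3 percentage points lower from compound 2 to compound 3 (beyond the scatter), a modest amount. An aryl swap of this kind therefore is expected to shift the number by a modest amount in this assay, with no firm direction to read from a single such step. Compound 4 is accordingly expected to give about 38%, within 22% to 56%, which means an expected step of a number 4.3 percentage points higher from compound 3 to compound 4 (within the scatter).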

Compound 4, a percentage reported as inhibition, at one concentration (the size of the read-out at that concentration, not a potency): 25%
The estimate for compound 4 lay 13 percentage points above the measured number; measured number inside the range.
By their numbers in this assay, from the lowest: compounds 4 and 3 (each within the scatter of the next); then compound 2; then compound 1.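

On the amide-type nitrogen, this assay does not separate 3-chloro-4-fluorophenyl from 2,4-difluorophenyl, the step being a number 8.7 percentage points lower from compound 3 to compound 4 (within the scatter). Compared with 3-methoxyphenyl, the new group gives a number 22 percentage points lower from compound 2 to compound 4 (beyond the scatter), so both fluorine-bearing aryl groups shown now stand apart from 3-methoxyphenyl beyond the scatter. On the oxygen on an aromatic ring, (3-chloro-4-fluorophenyl)carbamoyl gives a number 47.8 percentage points lower from compound 1 to compound 4 (beyond the scatter), which makes it the third carbamoyl group shown to fall beyond the scatter short of 3-(((thiophen-2-yl)carbonyl)amino)propyl.

Still open, on these data alone, is how a pyridine ring or an aminophenyl group on the amide-type nitrogen would read, and whether a longer chain than the propyl or a phenyl in place of the thiophene would hold the number of compound 1. Nothing at hand accounts for any of these differences.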